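This account rests on a few compounds, and the source may have more. Where it says the series, first, only, none or still open, it means among the compounds named here.

Measured so far in a functional assay on MKN-45 cells (Homo sapiens) for cytotoxicity, read by MTT assay, with a stated time of 72 h; on this read-out lower numbers stand for stronger inhibition and higher numbers for weaker inhibition:
- compound 1 `COc1ccc(OC)c(/C=N/NC(=O)Nc2ccc(Oc3ccnc(-c4nncn4CCN(C)C)c3)c(F)c2)c1` gives 1510 nM
- compound 2 `COc1ccc(/C=N/NC(=O)Nc2ccc(Oc3ccnc(-c4nncn4CCN(C)C)c3)c(F)c2)c(OC)c1` gives 1680 nM
- compound 3 `CN(C)CCn1cnnc1-c1cc(Oc2ccc(NC(=O)N/N=C/c3ccc(O)c(O)c3)cc2F)ccn1` gives 3240 nM

Compound 3 holds the highest number of the three in this assay. Against compound 2 the gap is a 1.9-fold higher number from compound 2 to compound 3 (0.29 log units; within the scatter) and falls within the scatter; against compound 1 it is a 2.1-fold higher number from compound 1 to compound 3 (0.33 log units; beyond the scatter) and just passes beyond it. Compounds 1 and 2 sit together, a 1.1-fold higher number from compound 1 to compound 2 (0.05 log units; within the scatter).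

Compound 4 `CN(C)CCn1cnnc1-c1cc(Oc2ccc(NC(=O)N/N=C/c3cccc(Br)c3)cc2F)ccn1` differs from compound 3 in one place: 3-bromophenyl in place of 3,4-dihydroxyphenyl on a carbon with a double bond to nitrogen. Within the data shown here, no measured pair carries a bromine on the ring at this position, so no step speaks to it directly. What the three measured compounds show is that swapping substituents on this ring moved the number only modestly, and that the 3,4-dihydroxyphenyl of compound 3 gave the highest number of the set. Leaving that group behind for 3-bromophenyl is therefore expected to give a number no worse than, and plausibly somewhat lower than, that of compound 3, but the breadth of that expectation is wide.

Compound 4 is estimated at 1800 nM in this assay, within 700 nM to 4500 nM.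

The expected step is a 1.8-fold lower number from compound 3 to compound 4 (0.26 log units; within the scatter).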

Compound 4, half-maximal inhibitory concentration: 450 nM
Compound 4: middle estimate off by 4.0-fold (0.60 log units), on the high side, and the stated range ends above it.
By their numbers in this assay, from the lowest: compound 4; then compounds 1, 2 and 3 (each within the scatter of the next, the first and the last beyond it).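

In this assay, among these compounds, this position on the carbon with a double bond to nitrogen proves more responsive than the earlier compounds suggested: a 7.2-fold lower number from compound 3 to compound 4 (0.86 log units; beyond the scatter) when 3-bromophenyl enters in place of 3,4-dihydroxyphenyl, while the earlier step from the same group reached only a 2.1-fold higher number from compound 1 to compound 3 (0.33 log units; beyond the scatter) within the dimethoxyphenyl and dihydroxyphenyl set. The new group also separates from both dimethoxyphenyl compounds, with a 3.7-fold lower number from compound 2 to compound 4 (0.57 log units; beyond the scatter) and a 3.4-fold lower number from compound 1 to compound 4 (0.53 log units; beyond the scatter) in the same assay, so compound 4 stands beyond the scatter of all three earlier compounds and not only of compound 3. No supporting measurement bears on what lies behind these steps.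

The compounds shown leave open whether the lower number belongs to bromine itself or to a ring carrying a single substituent, a question that chlorine, a methyl group or an amine on the ring could help settle. They also leave open whether a 3-bromophenyl group would give a step of similar size on a different core or in other cell lines.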